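A few compounds are considered here, and "the series" means these few. Any claim that something is new, unique, unknown or untested is made for them only; others in the source may bear on it.

Measured in an ADME assay on S9 fraction from liver (Rattus norvegicus) for metabolic stability, read by LC-MS, using NADPH, with a stated time of 60 min, tested at 10 uM; a lower number here means that less of the compound is left, a higher number that more of the compound is left:
- compound 1 `N#CC1(c2cc(CCO)cc(-c3ccnc4[nH]nc(C(F)(F)F)c34)c2)CC1`: 17%
- compound 2 `CC(C)C(O)Cc1cc(-c2ccnc3[nH]nc(C(F)(F)F)c23)cc(C2(C#N)CC2)c1`: 19%
- compound 3 `CC(=O)OCCc1cc(-c2ccnc3[nH]nc(C(F)(F)F)c23)cc(C2(C#N)CC2)c1`: 5%

Compound 3 stands lowest of the three at 5%, and its gaps to both others lie beyond the scatter. Compound 4 `CCc1cc(-c2ccnc3[nH]nc(C(F)(F)F)c23)cc(C2(C#N)CC2)c1` keeps the shared core and changes in one place: hydrogen in place of acetoxy on a saturated chain carbon, two bonds along the chain from an aromatic carbon. This puts hydrogen in place of acetoxy on a saturated chain carbon, two bonds along the chain from an aromatic carbon, so 2-acetoxyethyl becomes ethyl.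

For the measured compounds named here, no measured step makes this exact change. The closest evidence is a number 12 percentage points lower from compound 1 to compound 3 (beyond the scatter) and a number 14 percentage points lower from compound 2 to compound 3 (beyond the scatter), both modest. By contrast, a number 2 percentage points higher from compound 1 to compound 2 (within the scatter) stays within the scatter. Going by the values given here, no measured compound carries a bare ethyl, so the step can only be inferred from these neighbours. A modest rise in this assay is therefore expected, of about the size of those two steps but with wide uncertainty. The expected step is a number 10 percentage points higher from compound 3 to compound 4 (within the scatter). For compound 4 the estimate is 15%, with an expected range of 4% to 35%.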

Compound 4, percent of the compound remaining: 78%
Compound 4: middle estimate off by 63 percentage points, on the low side; measured number outside the range, above it.
By their numbers in this assay, from the lowest: compound 3; then compounds 1 and 2 (each within the scatter of the next); then compound 4.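

In this assay, removing the oxygen from this chain matters far more than any change among the oxygen-bearing groups: taking off the hydroxy gives a number 61 percentage points higher from compound 1 to compound 4 (beyond the scatter) and taking off the acetoxy gives a number 73 percentage points higher from compound 3 to compound 4 (beyond the scatter) while methyl in place of 1-hydroxy-2-methylpropyl gives a number 59 percentage points higher from compound 2 to compound 4 (beyond the scatter) with the bare ethyl well clear of all three. The earlier steps shown here were modest or within the scatter, and they gave no sign that this position could move the number so far. Nothing available explains the size of this rise.

The compounds shown leave open whether any oxygen on this chain keeps the number low or only these three groups do. They also leave open whether a longer chain such as propyl, an amine or a carboxylic acid at this place would stay near compound 4 or fall back towards compound 1.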